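Swapping the Aryl Group on a Triazole-Linked Spirooxindole

A few compounds are considered here, and "the series" means these few. Any claim that something is new, unique, unknown or untested is made for them only; others in the source may bear on it.

Measured compounds:
- compound 1 `N#CC1=C(N)Oc2c(N)cc3nc4ccccc4nc3c2C12C(=O)N(Cc1cnnn1-c1ccc(F)cc1)c1ccccc12` — > 50000 nM
- compound 2 `N#CC1=C(N)Oc2c(N)cc3nc4ccccc4nc3c2C12C(=O)N(Cc1cnnn1-c1cccc(C(F)(F)F)c1)c1ccccc12` — 15800 nM

The two measured compounds share one core and differ only in the aryl group carried on an aromatic nitrogen of the triazole ring. In a functional assay on HepG2 cells (Homo sapiens) for antiproliferative activity, read by MTT assay, with a stated time of 48 h (a lower number here means a stronger inhibitor, a higher number a weaker inhibitor), compound 1 gives > 50000 nM, which is a limit of the assay rather than a number (the limit of > 50000 nM in this assay, at which 1 of the 2 values shown sits). In this assay compound 2 gives 15800 nM, the only definite number shown, so compound 2 stands as the one compound with a measured inhibitory concentration; the step of an at least 3.1-fold lower number from compound 1 to compound 2 (0.50 log units; beyond the scatter) shows that changing the aryl group can move the read-out beyond the scatter.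

Compound 3 `COc1ccc(-n2nncc2CN2C(=O)C3(C(C#N)=C(N)Oc4c(N)cc5nc6ccccc6nc5c43)c3ccccc32)cc1` has not been measured. Relative to compound 2 the change is 4-methoxyphenyl in place of 3-(trifluoromethyl)phenyl on an aromatic nitrogen. For the measured compounds named here, the only step that bears on it is the one from compound 1 to compound 2, where 4-fluorophenyl gave only a limit and 3-(trifluoromethyl)phenyl gave a number. Since 4-methoxyphenyl is neither of these groups, the direction is uncertain, and a weakening toward the limit is expected, a 1.8-fold higher number from compound 2 to compound 3 (0.25 log units; within the scatter). Compound 3 is therefore estimated at 28000 nM, between 9000 nM and 80000 nM.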

Compound 3, half-maximal inhibitory concentration: > 50000 nM
Compound 3: no number, only a limit; the forecaster's own chance of this, stated with the estimate: 35%; middle value at least 1.7-fold (0.25 log units) from the limit.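

In this assay, for the compounds shown here, 4-methoxyphenyl in place of 3-(trifluoromethyl)phenyl on the triazole nitrogen gives an at least 3.1-fold higher number from compound 2 to compound 3 (0.50 log units; beyond the scatter), so the one definite reading in this small set is lost with this second swap as well as with the first. Compound 3 gives only a limit, not a number, and it joins compound 1 there: the limit of > 50000 nM in this assay, at which 2 of the 3 values shown sit. Of the three aryl groups shown at this position, only 3-(trifluoromethyl)phenyl gives a definite number, while the step between the 4-fluorophenyl and 4-methoxyphenyl compounds cannot be read, since both ends are limits.

The compounds shown do not separate the identity of the substituent from its place on the phenyl ring, and a 4-(trifluoromethyl)phenyl or a 3-methoxyphenyl group would be needed to pull those two apart. They also leave open how an unsubstituted phenyl group or a 3-aminophenyl group would read at this position, and whether any group here could give a much lower number than compound 2 does.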